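A few compounds are considered here, and "the series" means these few. Any claim that something is new, unique, unknown or untested is made for them only; others in the source may bear on it.

Among the two compounds with numbers so far, compound 2, `COc1ccc(N(C)c2nc(C)nc3ccccc23)cc1C(=O)OCCC[Se]C#N`, stands at the weaker end: in a functional assay on RKO cells (Homo sapiens) for inhibition, read by MTT assay, with a stated time of 48 h (on this read-out lower numbers stand for stronger inhibition and higher numbers for weaker inhibition), compound 2 gives 1140 nM. Its nearest neighbour, compound 1, `C[Se]c1ccc(N(C)c2nc(C3CC3)nc3ccccc23)cc1`, reaches a far lower number, as in this assay compound 1 gives 21 nM; the gap between these two lies well beyond the usual scatter of repeated measurements, so compound 2 is clearly the weaker of the pair. The two differ in several places at once, so no single structural cause can be read from that gap.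

The next compound, compound 3, `COc1ccc(N(C)c2nc(C)nc3ccccc23)cc1[Se]C#N`, is reached from compound 2 by one change: a group of 3 heavy atoms (1 carbon, 1 nitrogen, 1 selenium; no ring) in place of a group of 9 heavy atoms (5 carbon, 1 nitrogen, 2 oxygen, 1 selenium; no ring), on an aromatic carbon. For the measured compounds named here, no step between measured compounds matches this change, so the expectation rests on the whole picture only. The smaller group brings compound 3 somewhat closer in shape to compound 1, and the expected step is a modest move toward lower numbers of roughly a 1.9-fold lower number from compound 2 to compound 3 (0.28 log units; within the scatter), which may still fall within the scatter. For compound 3 in this assay a value of about 600 nM is estimated, expected to lie between 150 nM and 3000 nM.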

Compound 3, half-maximal inhibitory concentration: 47 nM
Estimate against measurement, compound 3: 13-fold (1.11 log units) above; the measured number lies below the stated range.
By their numbers in this assay, from the lowest: compound 1; then compound 3; then compound 2.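

In this assay, the aromatic carbon ortho to a methoxy group proves highly sensitive to what it carries: replacing the group of 9 heavy atoms with the group of 3 heavy atoms gives a 24-fold lower number from compound 2 to compound 3 (1.38 log units; beyond the scatter), a large step on a single structural change. Both groups contain selenium and a triple bond, so the presence of these two features alone does not settle the number; the step shows that the rest of the larger group, which the smaller one lacks, matters greatly at this position. Nothing available here explains why the two groups differ so strongly.

The compounds shown leave open whether a chain of intermediate length ending in the same selenium and nitrile unit would give a number nearer to that of compound 2 or to that of compound 3. They also leave open whether selenium is needed on this carbon, which a plain nitrile or a thiocyanate group in its place could test, and how an amine or a carboxylic acid there would fare.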